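Trifluoromethyl replaces fluoro on the aromatic ring of compound 2

The source may report more compounds than this note shows. Statements on the series, on what has been measured and on what is new or still open speak of the compounds shown alone.

In an ADME assay on HeLa cells (Homo sapiens) for cytotoxicity, read by crystal violet staining, with a stated time of 72 h (a lower number here means that less compound is tolerated, a higher number that more compound is tolerated), compound 1 (`CCOC(=O)c1cc(CCCOc2ccc(-c3noc(C(F)(F)F)n3)cc2)on1`) gives only a limit of > 100000 nM in this series. Among the compounds with values here, compound 2 (`CCOC(=O)c1cc(CCCOc2ccc(-c3noc(C(F)(F)F)n3)cc2F)on1`) gives 60200 nM as the only actual number so far, so it cannot yet be ranked against a second measured value. Compound 3 (`CCOC(=O)c1cc(CCCOc2ccc(-c3noc(C(F)(F)F)n3)cc2C(F)(F)F)on1`) carries trifluoromethyl in place of fluoro on an aromatic carbon, ortho to a large group (trifluoromethyl in place of fluoro on an aromatic carbon). Within the data shown here, the one measured step that bears on this change is an at least 1.6-fold lower number from compound 1 to compound 2 (0.22 log units; that floor lies within the scatter) and it came from fluoro in place of hydrogen on an aromatic carbon. As far as these compounds go, that step starts from a limit (the limit of > 100000 nM in this assay, at which 1 of the 2 values shown sits) and its full size stays unknown. It offers no firm direction, so no shift beyond the scatter is expected in this assay here. The expected change is a 1.1-fold lower number from compound 2 to compound 3 (0.04 log units; within the scatter) and it stays within the scatter. The estimated value for compound 3 is 55000 nM with an expected range from 25000 nM to 100000 nM.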

Compound 3, half-maximal cytotoxic concentration: 28400 nM
The estimate for compound 3 lay 1.9-fold (0.29 log units) above the measured number; measured number inside the range.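

In this assay, this position now yields a step that can be read beyond the scatter: a 2.1-fold lower number from compound 2 to compound 3 (0.33 log units; beyond the scatter). The earlier step here, with fluoro in place of hydrogen, gave only a floor within the scatter, whereas trifluoromethyl in place of hydrogen gives an at least 3.5-fold lower number from compound 1 to compound 3 (0.54 log units; beyond the scatter). The full size of that second step remains unknown, because it starts from a limit: the limit of > 100000 nM in this assay, at which 1 of the 3 values shown sits.

Only hydrogen, fluoro and trifluoromethyl stand at this place in the compounds shown, so it remains open how a methyl group, a chlorine atom, a methoxy group or a nitrile there would read in this assay. Also open, as far as these compounds go, is whether trifluoromethyl in place of fluoro would give a similar step with a carboxylic acid in place of the ethyl ester.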